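This account rests on a few compounds, and the source may have more. Where it says the series, first, only, none or still open, it means among the compounds named here.

Compound 2 `OC[C@H]1O[C@@H](n2cnc3c(NCc4ccc(F)cc4F)ncnc32)[C@H](O)[C@@H]1O` shares its core with compound 1 `COc1ccc(CNc2ncnc3c2ncn3[C@@H]2O[C@H](CO)[C@@H](O)[C@H]2O)c(OC)c1`, and the two differ in a single place. In a functional assay on MCF cells (Homo sapiens) for antiproliferative activity, with a stated time of 72 h (a lower number here means a stronger inhibitor, a higher number a weaker inhibitor), compound 1 gives > 166000 nM, which is a limit of the assay rather than a number. In this assay compound 2 gives > 166000 nM, again a limit and not a number. The change between them, 2,4-difluorophenyl in place of 2,4-dimethoxyphenyl on a saturated chain carbon bound to a nitrogen on an aromatic ring, is therefore a step that the two limits leave unreadable from compound 1 to compound 2. Compound 2 thus stands at the limit of > 166000 nM in this assay, at which 2 of the 2 values shown sit.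

Compound 3 `COc1cccc(CNc2ncnc3c2ncn3[C@@H]2O[C@H](CO)[C@@H](O)[C@H]2O)c1O` has not yet been measured in this assay. It differs from compound 2 by 2-hydroxy-3-methoxyphenyl in place of 2,4-difluorophenyl on a saturated chain carbon bound to a nitrogen on an aromatic ring. Going by the values given here, the only measured step, from compound 1 to compound 2, is unreadable, so no size or direction for the coming step can be drawn from it. Since compound 2 reaches only > 166000 nM in this assay, the most likely outcome for compound 3 is once more a limit. The step from compound 2 to compound 3 is expected to be a step that the limit leaves unreadable from compound 2 to compound 3. Compound 3 is estimated at 200000 nM, within a range from 80000 nM to 600000 nM.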

Compound 3, half-maximal inhibitory concentration: 20200 nM
Estimate against measurement, compound 3: 9.9-fold (1.00 log units) above; measured number outside the range, below it.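

The saturated chain carbon bound to a nitrogen on an aromatic ring now proves to be a place where a change can shift the result in this assay, something compounds 1 and 2 could not show, as the step that joins them cannot be read and both sit at a limit of the assay: the limit of > 166000 nM in this assay, at which 2 of the 3 values shown sit.

Putting 2-hydroxy-3-methoxyphenyl at this place instead of 2,4-difluorophenyl gives an at least 8.2-fold lower number from compound 2 to compound 3 (0.91 log units; beyond the scatter), and putting it there instead of 2,4-dimethoxyphenyl gives an at least 8.2-fold lower number from compound 1 to compound 3 (0.91 log units; beyond the scatter). Both steps lie beyond the scatter, and each gives only the smallest size the limits allow, so the real gap could be larger.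

Going by these compounds alone, with only compound 3 giving a number, it stays open whether the hydroxy group, the methoxy group or the two together carry the step, even though 2-hydroxy-3-methoxyphenyl is the only one of these groups with a hydrogen-bond donor. A phenyl ring with a hydroxy group alone, a ring bearing an amine or a carboxylic acid, or a longer chain in place of the saturated chain carbon would help to settle how far this effect reaches.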